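This account rests on a few compounds, and the source may have more. Where it says the series, first, only, none or still open, it means among the compounds named here.

For the measured compounds named here, compound 3 `O=C(O)CCCOc1ccc(OCc2ccc3ccccc3n2)cc1` gives the highest number of the three measured members in an assay on membranes from lung (Cavia porcellus) for binding affinity to cysteinyl leukotriene receptor (Homo sapiens) (on this read-out higher numbers stand for weaker inhibition and lower numbers for stronger inhibition), at 1200 nM. Compound 1 `O=C(O)CC1CCC(c2ccc(OCc3ccc4ccccc4n3)cc2)C1` gives 22 nM and compound 2 `CCCC(CCC(=O)O)Cc1ccc(OCc2ccc3ccccc3n2)cc1` gives 21 nM in this assay. Going by the values given here, the one fully comparable step, a 55-fold higher number from compound 1 to compound 3 (1.74 log units; beyond the scatter), is the only large movement seen, and it replaced a ring-bearing side chain with an open 3-carboxypropoxy chain. Compound 4 `O=C(O)CCCCc1ccc(OCc2ccc3ccccc3n2)cc1` carries 4-carboxybutyl in place of 3-carboxypropoxy on an aromatic carbon. No measured step isolates this change; compound 2, whose open chain lacks the ether oxygen, sits close to compound 1, which suggests the open chain alone does not account for the weak number of compound 3. A moderate decrease is therefore expected, a 3.0-fold lower number from compound 3 to compound 4 (0.48 log units; beyond the scatter), giving compound 4 an estimated 400 nM in this assay, within 100 nM to 1500 nM.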

Compound 4, inhibition constant: 110 nM
Compound 4: the middle estimate sits 3.6-fold (0.56 log units) above what was measured, within the range that was stated.
By their numbers in this assay, from the lowest: compounds 2 and 1 (each within the scatter of the next); then compound 4; then compound 3.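

At this aromatic carbon, para to a large group, 4-carboxybutyl in place of 3-carboxypropoxy gives an 11-fold lower number from compound 3 to compound 4 (1.04 log units; beyond the scatter) in this assay and shows that an open chain without the ether oxygen can reach a far lower number. That chain still trails both branched or ring-bearing members: a 5.2-fold higher number from compound 2 to compound 4 (0.72 log units; beyond the scatter) comes with hydrogen in place of propyl, and a 5.0-fold higher number from compound 1 to compound 4 (0.70 log units; beyond the scatter) comes with 4-carboxybutyl in place of 3-(carboxymethyl)cyclopentyl.

Nothing at hand explains these steps. From the compounds shown here alone, whether a longer chain or a shorter branch than propyl would close the remaining gap stays open.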